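Methoxymethyl in place of cyclopropylcarbamoyl on the piperidine chain

The compounds below may be only part of what the source reports. "The series", "measured", "known", "first", "only" and "open" are said of these compounds alone.

Measured so far:
Compound 1 `Cn1ncc(Cl)c1-c1cc(C(=O)N[C@@H]2CNCC[C@H]2c2ccc(C(F)(F)F)cc2)oc1Cl`: 9.3 nM
Compound 2 `Cn1ncc(Cl)c1-c1cc(C(=O)N[C@@H]2CN[C@H](CC(=O)NC3CC3)C[C@H]2c2ccc(Cl)c(Cl)c2)oc1Cl`: 3.95 nM

In an assay for inhibition of RAC-alpha serine/threonine-protein kinase (Homo sapiens), read by HTRF, with a stated time of 1 h (on this read-out lower numbers stand for stronger inhibition and higher numbers for weaker inhibition), compound 2 stands lowest of the two numbers; the nearest is compound 1, whose number is higher by a step beyond the scatter. Compound 3 `COCC[C@@H]1C[C@@H](c2ccc(Cl)c(Cl)c2)[C@H](NC(=O)c2cc(-c3c(Cl)cnn3C)c(Cl)o2)CN1` has not been measured. It differs from compound 2 in one place: methoxymethyl in place of cyclopropylcarbamoyl on a saturated chain carbon bound to a saturated ring carbon. Going by the values given here, no step between measured compounds is available for this change, so the expectation rests on compound 2 alone, a small step with no clear direction, possibly none beyond the scatter, is expected as a 1.4-fold higher number from compound 2 to compound 3 (0.14 log units; within the scatter). For compound 3 the expected value is 5.5 nM, with a range from 2 nM to 15 nM.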

Compound 3, half-maximal inhibitory concentration: 7.01 nM
Estimate against measurement, compound 3: 1.3-fold (0.11 log units) below, and the stated range covers the measured number.
By their numbers in this assay, from the lowest: compounds 2, 3 and 1 (each within the scatter of the next, the first and the last beyond it).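

In this assay methoxymethyl in place of cyclopropylcarbamoyl on a saturated chain carbon bound to a saturated ring carbon gives a 1.8-fold higher number from compound 2 to compound 3 (0.25 log units; within the scatter) and so shows that neither the three-membered ring nor the hydrogen-bond donor of cyclopropylcarbamoyl is required for a number in this range. No measured property is available to explain this result. As far as these compounds go, whether an amine or a carboxylic acid at this place would fare alike stays open. From the compounds shown here alone, compound 1 differs from both compounds in more than one place, so what the chain itself contributes also stays open.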